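A Selenium-Bearing Group Replaces the Aminoethoxy Chain

The compounds below may be only part of what the source reports. "The series", "measured", "known", "first", "only" and "open" are said of these compounds alone.

Of the compounds shown here, three built on one shared core have been measured in a functional assay on HCT-116 cells (Homo sapiens) for inhibition, read by MTT assay, with a stated time of 48 h; on this read-out higher numbers stand for weaker inhibition and lower numbers for stronger inhibition. Compound 1 `COc1ccc(N(C)c2nc(C)nc3ccccc23)cc1OCCN` gives 198 nM in this assay, the highest of the three numbers. Compound 2 `C[Se]c1ccc(N(C)c2nc(C)nc3ccccc23)cc1C` gives 3 nM and compound 3 `Cc1nc(N(C)c2ccc([Se]C#N)c(F)c2)c2ccccc2n1` gives 20 nM; both carry a selenium atom, and both sit far below compound 1, beyond the usual scatter. Among the compounds with values here, each differs from compound 1 in more than one place, so no single step between measured compounds can be traced.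

Compound 4 `COc1ccc(N(C)c2nc(C)nc3ccccc23)cc1C[Se]C#N` keeps the methoxy group of compound 1 and changes one group: a group of 4 heavy atoms (2 carbon, 1 nitrogen, 1 selenium; no ring) in place of a group of 4 heavy atoms (2 carbon, 1 nitrogen, 1 oxygen; no ring), on an aromatic carbon. The hydrogen-bond donor of the 2-aminoethoxy chain is lost, and a selenium atom bearing a nitrile, as found in compound 3, comes in at that aromatic carbon.

Since compound 3 gives 20 nM and compound 2 gives 3 nM, a move toward lower numbers is expected, though the methoxy group that compound 4 retains and the others lack leaves the size uncertain. The expected step is a 6.6-fold lower number from compound 1 to compound 4 (0.82 log units; beyond the scatter), beyond the scatter. The estimate for compound 4 in this assay is 30 nM, with a range from 8 nM to 120 nM.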

Compound 4, half-maximal inhibitory concentration: 113 nM
Estimate against measurement, compound 4: 3.8-fold (0.58 log units) below; measured number inside the range.
By their numbers in this assay, from the lowest: compound 2; then compound 3; then compounds 4 and 1 (each within the scatter of the next).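

Within the data shown here, this is the first single change that can be read directly: with the methoxy group kept and the rest of the molecule unchanged, putting the selenium-and-nitrile group in place of 2-aminoethoxy on this aromatic carbon gives a 1.8-fold lower number from compound 1 to compound 4 (0.24 log units; within the scatter) in this assay. The exchange therefore removes the hydrogen-bond donor of the chain and brings in a selenium atom without moving the number beyond the scatter, so at this position, ortho to a methoxy group, the two groups cannot be told apart on this read-out, and compound 4 shows that carrying selenium does not by itself place a compound far below compound 1. No measured evidence is available to explain why the two groups read alike here.

The compounds shown leave open whether the same selenium-and-nitrile group would read differently on this carbon without the neighbouring methoxy group, since no single step isolates that group. They also leave open how a plain primary amine, a carboxylic acid or a longer chain carrying an amine would read at this same position on the shared core.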